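Swapping the benzyl substituent on a statin-like amide

The compounds below may be only part of what the source reports. "The series", "measured", "known", "first", "only" and "open" are said of these compounds alone.

Compound 1 `COc1ccc(CNC(=O)c2nc(-c3ccc(F)cc3)n(CC[C@@H](O)C[C@@H](O)CC(=O)O)c2C2CC2)cc1F`: 3.7 nM
Compound 2 `Cc1c(C(=O)NCc2ccccc2)nc(-c2ccc(F)cc2)n1CC[C@@H](O)C[C@@H](O)CC(=O)O`: 94 nM

In an assay on microsomes from liver for inhibition of 3-hydroxy-3-methylglutaryl-coenzyme A reductase (Rattus norvegicus), read by scintillation counting, with stated times of 0.5 h and 0.75 h (on this read-out lower numbers stand for stronger inhibition and higher numbers for weaker inhibition), compound 1 gives 3.7 nM, the lowest number of the two measured compounds, while compound 2 gives 94 nM, a gap beyond the scatter. Compound 2 differs from compound 1 in more than one place, so its values alone are noted. Compound 3 `O=C(O)C[C@H](O)C[C@H](O)CCn1c(-c2ccc(F)cc2)nc(C(=O)NCc2ccc(F)cc2)c1C1CC1` carries 4-fluorophenyl in place of 3-fluoro-4-methoxyphenyl on a saturated chain carbon bound to an amide-type nitrogen. Among the compounds with values here, no single-point step of this kind has been measured here, so the expectation for compound 3 is a small step, likely toward a somewhat higher number but possibly none beyond the scatter, estimated as a 1.6-fold higher number from compound 1 to compound 3 (0.21 log units; within the scatter). Compound 3 is therefore expected to give about 6 nM, within 2 nM to 20 nM.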

Compound 3, half-maximal inhibitory concentration: 3.4 nM
Compound 3: middle estimate off by 1.8-fold (0.25 log units), on the high side; the measured number falls inside the stated range.
By their numbers in this assay, from the lowest: compounds 3 and 1 (each within the scatter of the next); then compound 2.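

In this assay, putting 4-fluorophenyl in place of 3-fluoro-4-methoxyphenyl on a saturated chain carbon bound to an amide-type nitrogen gives a 1.1-fold lower number from compound 1 to compound 3 (0.04 log units; within the scatter). This position therefore keeps its low nanomolar reading with either group, so this change of substituents makes no measurable difference here. Nothing available explains this result. Still open, on these data alone, is how this assay would read with an amine or a carboxylic acid on the phenyl ring, or with a longer chain linking that ring to the amide-type nitrogen.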